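Imidazole for hydrazinylpyridine on a pyrazolopyridine core

A few compounds are considered here, and "the series" means these few. Any claim that something is new, unique, unknown or untested is made for them only; others in the source may bear on it.

Measured compounds:
Compound 1 `Fc1ccc(-c2nn3c(NC4CCCC4)cccc3c2-c2ccc(F)nc2)cc1`: "not determined" (no result reported) in an ADME assay on Vero cells (Chlorocebus sabaeus) for cytotoxicity; on this read-out higher numbers stand for lower toxicity in this test and lower numbers for higher toxicity in this test.
Compound 2 `NNc1cc(-c2c(-c3ccc(F)cc3)nn3c(NC4CCCC4)cccc23)ccn1`: 40000 nM in this assay.

For the measured compounds named here, compound 2 is the only compound with a number in this assay, and that number is 40000 nM; compound 1 is "not determined" (no result reported) and so gives no basis for comparison. Compound 3 `Fc1ccc(-c2nn3c(NC4CCCC4)cccc3c2-c2c[nH]c(NC3CCCC3)n2)cc1` has not been measured. It differs from compound 2 in one place: 2-(cyclopentylamino)-1H-imidazol-4-yl in place of 2-(aminoamino)pyridin-4-yl on an aromatic carbon. Going by the values given here, no pair of measured compounds that differ in one place exists, so the size of this change in this assay cannot be taken from any step. With only the value of compound 2 to go on, the expected step of a 1.3-fold lower number from compound 2 to compound 3 (0.12 log units; within the scatter) is small, pointing toward somewhat higher toxicity, but not clearly beyond the scatter. Compound 3 is therefore estimated at 30000 nM, within a range from 10000 nM to 80000 nM.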

Compound 3, half-maximal cytotoxic concentration: 40000 nM
Estimate against measurement, compound 3: 1.3-fold (0.12 log units) below; measured number inside the range.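

In this assay the read-out shows no change at the digits printed from compound 2 to compound 3 (within the scatter) when 2-(cyclopentylamino)-1H-imidazol-4-yl takes the place of 2-(aminoamino)pyridin-4-yl on an aromatic carbon. For the compounds shown here, this is the first step seen at this position, and it shows that a six-membered aromatic ring can give way to a five-membered aromatic ring carrying a cyclopentylamino group, with more heavy atoms overall, without a change beyond the scatter in this test. Nothing shown here explains this result.

From the compounds shown here alone, whether this holds for other groups at this position stays open, for example a carboxylic acid or a simple amine on the imidazole in place of the cyclopentylamino group. Also open, going by these compounds, is whether the cyclopentylamino group itself matters to the read-out.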